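Pyridinylpiperazine in place of anilino on a pyrimidine urea

This account rests on a few compounds, and the source may have more. Where it says the series, first, only, none or still open, it means among the compounds named here.

Compound 1: `COc1ccc(NC(=O)Nc2nc(Sc3c[nH]c4ccccc34)cc(N3CCN(c4ccccn4)CC3)n2)cc1` gives 33400 nM
Compound 2: `O=C(Nc1ccccc1)Nc1nc(Nc2ccccc2)cc(Sc2c[nH]c3ccccc23)n1` gives 26400 nM

Of the compounds shown here, two have been measured in a functional assay on PC-3 cells (Homo sapiens) for inhibition, with a stated time of 72 h; on this read-out higher numbers stand for weaker inhibition and lower numbers for stronger inhibition. Compound 1 `COc1ccc(NC(=O)Nc2nc(Sc3c[nH]c4ccccc34)cc(N3CCN(c4ccccn4)CC3)n2)cc1` gives 33400 nM, and compound 2 `O=C(Nc1ccccc1)Nc1nc(Nc2ccccc2)cc(Sc2c[nH]c3ccccc23)n1` gives 26400 nM. Compound 2 stands closest to compound 1, and the two values sit within the usual scatter of each other, so no order between them can be read from these numbers.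

Compound 3 `O=C(Nc1ccccc1)Nc1nc(Sc2c[nH]c3ccccc23)cc(N2CCN(c3ccccn3)CC2)n1` is not yet measured. It differs from compound 2 in one place: 4-(pyridin-2-yl)piperazin-1-yl in place of anilino on an aromatic carbon. The same 4-(pyridin-2-yl)piperazin-1-yl group is present in compound 1, whose value in this assay is close to that of compound 2. With both measured compounds in the same weak range, the step of a 1.1-fold higher number from compound 2 to compound 3 (0.06 log units; within the scatter) is expected to stay within the scatter. Compound 3 is therefore estimated at 30000 nM, with a range from 10000 nM to 90000 nM.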

Compound 3, half-maximal inhibitory concentration: 21600 nM
The estimate for compound 3 lay 1.4-fold (0.14 log units) above the measured number, within the range that was stated.
By their numbers in this assay, from the lowest: compounds 3, 2 and 1 (each within the scatter of the next).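

In this assay, 4-(pyridin-2-yl)piperazin-1-yl in place of anilino on the aromatic carbon gives a 1.2-fold lower number from compound 2 to compound 3 (0.09 log units; within the scatter) and so, with everything else held the same, the two groups cannot be told apart at this position. Hydrogen in place of methoxy on an aromatic carbon, with the 4-(pyridin-2-yl)piperazin-1-yl group kept, gives a 1.5-fold lower number from compound 1 to compound 3 (0.19 log units; within the scatter) and so is also unreadable, a change that compounds 1 and 2 could not isolate because they differ in more than one place. No further evidence bears on these results.

The compounds shown leave open whether a morpholine or a primary amine at this position would give a number beyond the scatter. They also leave open whether chlorine or a carboxylic acid on the phenyl of the (phenylcarbamoyl)amino group would do so.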